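Replacing the Group on Sulfur in a Thioether Series

The compounds below may be only part of what the source reports. "The series", "measured", "known", "first", "only" and "open" are said of these compounds alone.

Measured in a functional assay on A-375 cells (Homo sapiens) for antiproliferative activity, read by CCK-8 assay, with a stated time of 72 h; a higher number here means a weaker inhibitor, a lower number a stronger inhibitor:
Compound 1 `CCc1ccc(SCc2ccc(C(=O)Nc3ccccc3N)cc2)cc1`: 2420 nM
Compound 2 `Cc1ccc(SCc2ccc(C(=O)Nc3ccccc3N)cc2)cc1`: 3700 nM

For the measured compounds named here, compound 2, at 3700 nM, stands within the scatter of compound 1, the only other measured compound. The next compound, compound 3 `Nc1ccccc1NC(=O)c1ccc(CSCCc2ccccc2)cc1`, carries phenethyl in place of 4-methylphenyl on a sulfur. Going by the values given here, only one measured step bears on this change, and only loosely: a 1.5-fold higher number from compound 1 to compound 2 (0.18 log units; within the scatter). Among the compounds with values here, that step put hydrogen in place of methyl on a saturated chain carbon, and no measured compound varies the whole group on the sulfur. The data therefore give no direction for the change. No step beyond the scatter is expected in this assay, and the estimated step is a 1.1-fold lower number from compound 2 to compound 3 (0.02 log units; within the scatter). With so little evidence, the expected range stays wide. The estimate for compound 3 is 3500 nM, within an expected range of 1100 nM to 10000 nM.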

Compound 3, half-maximal inhibitory concentration: 2860 nM
Estimate against measurement, compound 3: 1.2-fold (0.09 log units) above; measured number inside the range.
By their numbers in this assay, from the lowest: compounds 1, 3 and 2 (each within the scatter of the next).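

In this assay, for the compounds shown here, the whole group on the sulfur changes for the first time, and the exchange gives a 1.3-fold lower number from compound 2 to compound 3 (0.11 log units; within the scatter) and, against the 4-ethylphenyl group, a 1.2-fold higher number from compound 1 to compound 3 (0.07 log units; within the scatter) with neither step leaving the scatter. Among these three compounds, then, the sulfur carries phenethyl, with its ring set on a saturated chain, as well as it carries a ring bound directly, with no step beyond the scatter in this assay. Nothing available accounts for this result.

All three groups on the sulfur contain a six-membered aromatic ring of carbon only, so a plain alkyl chain in that place remains untested in what is shown here. On these data alone, it also remains open whether an amine or a carboxylic acid on the phenethyl ring would move the number beyond the scatter.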